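A few compounds are considered here, and "the series" means these few. Any claim that something is new, unique, unknown or untested is made for them only; others in the source may bear on it.

Working notes on the series. In a functional assay on HCT-116 cells (Homo sapiens) for inhibition, read by MTT assay, with a stated time of 48 h (on this read-out higher numbers stand for weaker inhibition and lower numbers for stronger inhibition), compound 1 `Brc1cccc(CSc2nnc(-c3ccncc3)n2-c2ccccc2)c1` gives 8170 nM. Compound 2 `Fc1ccc(CSc2nnc(-c3ccncc3)n2-c2ccccc2)cc1` gives 12800 nM in this assay. Compound 3 `O=[N+]([O-])c1ccccc1CSc1nnc(-c2ccncc2)n1-c1ccccc1` gives in this assay only a limit, > 50000 nM, which is the limit of > 50000 nM in this assay, at which 1 of the 3 values shown sits. The step of a 1.6-fold higher number from compound 1 to compound 2 (0.19 log units; within the scatter) is within the scatter. The steps of an at least 6.1-fold higher number from compound 1 to compound 3 (0.78 log units; beyond the scatter) and an at least 3.9-fold higher number from compound 2 to compound 3 (0.59 log units; beyond the scatter) are beyond it, so compound 3 stands as the weakest inhibitor of the three measured, and only as a limit, not as a number.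

Compound 4 `O=[N+]([O-])c1ccc(CSc2nnc(-c3ccncc3)n2-c2ccccc2)cc1` differs from compound 3 by 4-nitrophenyl in place of 2-nitrophenyl on a saturated chain carbon bound to a sulfur. Going by the values given here, none of the measured steps moves a nitro group from one place on the ring to another; the measured steps compare two halogenated rings with the 2-nitrophenyl ring, and both halogen rings gave numbers where the 2-nitrophenyl ring gave a limit. Among the compounds with values here, the only comparison of a group bound at the 4 place, compound 2, gives a number, not a limit.

Compound 4 is therefore expected to give about 25000 nM in this assay, with a range from 8000 nM to 80000 nM. The expected step is an at least 2.0-fold lower number from compound 3 to compound 4 (0.30 log units; that floor lies within the scatter), with a real chance that compound 4 again yields only a limit.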

Compound 4, half-maximal inhibitory concentration: 23800 nM
Compound 4: the middle estimate sits 1.1-fold (0.02 log units) above what was measured; low and high end bracket the measured number.
By their numbers in this assay, from the lowest: compounds 1, 2 and 4 (each within the scatter of the next, the first and the last beyond it). At a limit, above all of these: compound 3.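

Exchanging 2-nitrophenyl for 4-nitrophenyl on a saturated chain carbon bound to a sulfur gives an at least 2.1-fold lower number from compound 3 to compound 4 (0.32 log units; beyond the scatter), so in this assay the same atoms joined differently shift the read-out. Nitro in place of fluoro on an aromatic carbon gives a 1.9-fold higher number from compound 2 to compound 4 (0.27 log units; within the scatter), which leaves compound 2 and compound 4 unseparated, while 4-nitrophenyl in place of 3-bromophenyl gives a 2.9-fold higher number from compound 1 to compound 4 (0.46 log units; beyond the scatter). Compound 3 remains a limit, not a number, so the full size of its step stays unknown: the limit of > 50000 nM in this assay, at which 1 of the 4 values shown sits.

On these data alone, whether the weak reading of 2-nitrophenyl belongs to the nitro group itself or to its placement stays open. Also open, as far as these compounds go, is how an amine or a carboxylic acid on the phenyl ring, or a longer chain in place of the saturated chain carbon, would read.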